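The source may report more compounds than this note shows. Statements on the series, on what has been measured and on what is new or still open speak of the compounds shown alone.

Measured so far:

Compound 1, `COc1nc2ccccc2n1C(=O)NCCCCc1ccccc1`: 13.9 nM
Compound 2, `O=C(NCCCCc1ccccc1)n1cnc2ccccc21`: 2.5 nM
Compound 3, `CCCCCCNC(=O)n1cnc2ccccc21`: 6.6 nM

Of these three, compound 2 gives the lowest number in an assay on HEK293 cells for inhibition of acid ceramidase (Homo sapiens), read by fluorescence, with stated times of 30 min and 1 h; a higher number here means a weaker inhibitor, a lower number a stronger inhibitor; its nearest neighbour is compound 3, and compound 1 lies furthest from it, both steps being beyond the scatter. Compound 4, `Nc1nc2ccccc2n1C(=O)NCCCCc1ccccc1`, differs from compound 2 in one place: amino in place of hydrogen on an aromatic carbon. Among the compounds with values here, the step that bears on this most directly is the one from compound 1 to compound 2, where removing a methoxy from an aromatic carbon of the shared core gave a 5.6-fold lower number from compound 1 to compound 2 (0.75 log units; beyond the scatter); that is, the unsubstituted core gave the lower number. The step from compound 2 to compound 3, a 2.6-fold higher number from compound 2 to compound 3 (0.42 log units; beyond the scatter), concerns the chain end and not the core, so it says little here. Amino is a different group from methoxy, but putting a group back on the core is, on this evidence, expected to raise the number, probably by less than the methoxy did. An upward step of about a 2.8-fold higher number from compound 2 to compound 4 (0.45 log units; beyond the scatter) is expected. Compound 4 is therefore estimated at 7 nM, with a range from 2.5 nM to 25 nM.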

Compound 4, half-maximal inhibitory concentration: 0.9 nM
Beside the measured number, compound 4's estimate is 7.8-fold (0.89 log units) above it, and the stated range ends above it.
By their numbers in this assay, from the lowest: compound 4; then compound 2; then compound 3; then compound 1.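

In this assay, amino in place of hydrogen gives a 2.8-fold lower number from compound 2 to compound 4 (0.44 log units; beyond the scatter), so a group on this aromatic carbon, between two ring nitrogen atoms, need not raise the number, although methoxy was the only substituent seen here before and it did. Amino in place of methoxy at the same carbon gives a 15-fold lower number from compound 1 to compound 4 (1.19 log units; beyond the scatter), the largest step among these compounds, which shows that the outcome here depends on which group is attached and not merely on whether the carbon carries one. No measurement available here accounts for the opposite directions of the amino and methoxy steps.

The compounds shown leave open how narrowly this gain is tied to amino itself, since a methylamino, dimethylamino, hydroxyl or methyl group on the same carbon would help show whether nearby groups follow amino or methoxy. They also leave open whether amino would lower the number in the same way when paired with the chain of compound 3, because amino appears here only with the phenyl-ended chain.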